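The source may report more compounds than this note shows. Statements on the series, on what has been measured and on what is new or still open speak of the compounds shown alone.

Measured so far:
- compound 1, `O=C(COc1cccc2ccccc12)N/N=C/c1ccc(O)cc1`: 20 ug/mL in an ADME assay on HEL cells (Homo sapiens) for cytotoxicity; a lower number here means that less compound is tolerated, a higher number that more compound is tolerated
- compound 2, `COc1ccc(/C=N/NC(=O)COc2cccc3ccccc23)cc1OC`: >= 20 ug/mL in this assay

Among the measured compounds shown here, compound 1 gives the only plain number in this assay, 20 ug/mL. For compound 2 the result of >= 20 ug/mL is a limit of the assay and not a number, the same situation as the limit of >= 20 ug/mL in this assay, at which 1 of the 2 values shown sits. Compound 3, `O=C(COc1cccc2ccccc12)N/N=C/C=C/c1ccccc1`, has not been measured in this assay. It differs from compound 1 in one place: 2-phenylethenyl in place of 4-hydroxyphenyl on a carbon with a double bond to nitrogen. For the measured compounds named here, no step between measured compounds is available to guide the size of this change, so the expected step from compound 1 to compound 3 is no change at the digits printed from compound 1 to compound 3 (within the scatter), roughly none beyond the usual scatter. Compound 3 is therefore estimated at 20 ug/mL, within the range 7 ug/mL to 50 ug/mL.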

Compound 3, minimum cytotoxic concentration: 100 ug/mL
For compound 3 the middle estimate is 5.0-fold (0.70 log units) below the measured one; measured number above the stated range.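

In this assay, the place on a carbon with a double bond to nitrogen turns out to be sensitive to its group: 2-phenylethenyl in place of 4-hydroxyphenyl gives a 5.0-fold higher number from compound 1 to compound 3 (0.70 log units; beyond the scatter). Among the compounds shown here, this swap removes a hydrogen-bond donor and acceptor and adds a double bond outside aromatic rings, and the single step cannot separate these differences. Compound 2 has only a limit and not a number, so it adds no step: the limit of >= 20 ug/mL in this assay, at which 1 of the 3 values shown sits.

Going by these compounds, whether a plain phenyl at this place would read nearer compound 1 or compound 3 stays open. So does the effect of an amine on the aromatic ring.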